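The compounds below may be only part of what the source reports. "The series", "measured", "known", "first", "only" and "open" are said of these compounds alone.

Measured in a functional assay on DU-145 cells (Homo sapiens) for inhibition, read by trypan blue exclusion, with a stated time of 96 h; a lower number here means a stronger inhibitor of growth, a higher number a weaker inhibitor of growth:
- Compound 1 `O=C(O)c1ccc(/C=C(/SCc2ccc(Cl)cc2)C(=O)c2ccc(C(=O)O)cc2)cc1`: > 100000 nM, a limit of the assay and not a number
- Compound 2 `COc1ccc(C(=O)/C(=C\c2ccc(O)c([N+](=O)[O-])c2)SCc2ccc(Br)cc2)cc1`: 10000 nM

Within the data shown here, compound 2, at 10000 nM, holds the only actual number so far. The single other result is a limit of the assay and not a number. Compound 2 therefore serves as the sole reference point for what follows.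

Compound 3 `O=C(/C(=C\c1ccc(O)c([N+](=O)[O-])c1)SCc1ccc(Br)cc1)c1ccc(C(F)(F)F)cc1` keeps the rest of compound 2 but turns 4-methoxyphenyl into 4-(trifluoromethyl)phenyl, with trifluoromethyl in place of methoxy on an aromatic carbon, para to a large group: trifluoromethyl in place of methoxy on an aromatic carbon.

Among the measured compounds shown here, no measured pair here shows what this swap does in this assay, so no step beyond the usual scatter is expected, in either direction. The estimated step of no change at the digits printed from compound 2 to compound 3 (within the scatter) is accordingly small, with a wide margin of uncertainty. For compound 3 the expected value is 10000 nM, with an estimated range of 3000 nM to 40000 nM.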

Compound 3, concentration for 50% growth inhibition: 10000 nM
Compound 3: the middle estimate sits on the measured number at the digits printed, within the range that was stated.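

Among these compounds, the first comparison that can be read in this assay shows no change at the digits printed from compound 2 to compound 3 (within the scatter). At this place on the aromatic ring, para to a large group, trifluoromethyl and methoxy therefore give growth inhibition that cannot be told apart in this assay, although the two groups differ in heavy atoms and in hydrogen-bond acceptors. Neither compound 2 nor compound 3 sits at a limit of the assay, so this pair can be compared as real numbers, and the only limit shown belongs to a different compound: the limit of > 100000 nM in this assay, at which 1 of the 3 values shown sits.

On these data alone, whether a different group here, such as an amine, a nitrile or a longer alkoxy chain, would move the value remains open. Among the compounds shown here, compound 1 differs from both other compounds in more than one place, so no step to it can be read, and the effect of each of those places stays unknown.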